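This account rests on a few compounds, and the source may have more. Where it says the series, first, only, none or still open, it means among the compounds named here.

Compound 1 `CN1CC(=O)N/C1=N\C(=O)Nc1ccncc1`: 9 mL.min-1.g-1
Compound 2 `Cc1cnccc1NC(=O)/N=C1\NC(=O)CN1C`: 14 mL.min-1.g-1

Among the compounds with values here, these numbers come from an in vitro ADME assay on microsomes from liver (Rattus norvegicus) for metabolic stability (a higher number here means faster removal of the compound, a lower number slower removal), and place compound 2 within the scatter of compound 1, the only other measured compound. Compound 3 `CN1CC(=O)N/C1=N\C(=O)Nc1ccncc1Cl` has not yet been measured. The change from compound 2 is chloro in place of methyl on an aromatic carbon and amounts to chloro in place of methyl on an aromatic carbon. Within the data shown here, one measured step bears on this carbon: a 1.6-fold higher number from compound 1 to compound 2 (0.19 log units; within the scatter) with methyl in place of hydrogen. Among the measured compounds shown here, that step does not separate the two compounds, and no measured compound carries chloro, so the size of the chloro change remains untested. The estimated change is a 1.2-fold lower number from compound 2 to compound 3 (0.07 log units; within the scatter) and no step beyond the scatter is expected. For compound 3 the estimate is 12 mL.min-1.g-1 with an expected range from 6 mL.min-1.g-1 to 25 mL.min-1.g-1 in this assay.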

Compound 3, intrinsic clearance in microsomes: 31 mL.min-1.g-1
Estimate against measurement, compound 3: 2.6-fold (0.41 log units) below; measured number above the stated range.
By their numbers in this assay, from the lowest: compounds 1 and 2 (each within the scatter of the next); then compound 3.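

In this assay this aromatic carbon, ortho to a large group and two atoms from the ring nitrogen, now gives steps beyond the scatter: chloro in place of hydrogen gives a 3.4-fold higher number from compound 1 to compound 3 (0.54 log units; beyond the scatter) and chloro in place of methyl gives a 2.2-fold higher number from compound 2 to compound 3 (0.35 log units; beyond the scatter) on the same carbon. The earlier pair showed only that hydrogen and methyl here lie within the scatter of each other, whereas chloro stands apart from both, so the read-out at this position does respond to the group placed there. The data on hand offer no measurement that accounts for this result.

Open, from the compounds shown here alone, is whether fluoro, methoxy or an amine on this carbon would stand with chloro or with hydrogen and methyl. Also open, going by these compounds, is whether chloro on another ring carbon gives a step of similar size.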